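A Carboxylic Acid Replaces Hydroxy on the Side Chain

The compounds below may be only part of what the source reports. "The series", "measured", "known", "first", "only" and "open" are said of these compounds alone.

Compound 1 `COc1ccc(/C=C\c2cc(OC)c(OC)c(OC)c2)cc1OCc1ccc(CNC(C)(C)C(=O)O)cc1`: > 10000 nM (a limit, not a number)
Compound 2 `COc1ccc(/C=C\c2cc(OC)c(OC)c(OC)c2)cc1OCc1ccc(CO)cc1`: 6600 nM

Both results come from a functional assay on B16-F10 cells (Mus musculus) for antiproliferative activity, read by CCK-8 assay, with a stated time of 48 h; on this read-out higher numbers stand for weaker inhibition and lower numbers for stronger inhibition. Among the measured compounds shown here, compound 2, at 6600 nM, holds the only true number so far. Compound 1 gives > 10000 nM, which is a limit of the assay. In compound 3 `COc1ccc(/C=C\c2cc(OC)c(OC)c(OC)c2)cc1OCc1ccc(CN2CC(C(=O)O)C2)cc1`, not yet measured, 3-carboxyazetidin-1-yl takes the place of hydroxy on a saturated chain carbon bound to an aromatic carbon (3-carboxyazetidin-1-yl in place of hydroxy on a saturated chain carbon bound to an aromatic carbon).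

For the measured compounds named here, one measured step bears on this change: an at least 1.5-fold lower number from compound 1 to compound 2 (0.18 log units; that floor lies within the scatter). There, hydroxy replaced (1-carboxy-1-methylethyl)amino, another carboxy-bearing group with a nitrogen. Going back to such a group is therefore expected to give a small move towards weaker inhibition in this assay, perhaps nothing beyond the scatter, and the result may again be only a limit. The estimated change is a 1.8-fold higher number from compound 2 to compound 3 (0.26 log units; within the scatter). Compound 3 is estimated at 12000 nM, with an expected range of 4000 nM to 30000 nM.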

Compound 3, half-maximal inhibitory concentration: > 10000 nM
Compound 3 gave a limit, no number; the forecaster's own chance of this, stated with the estimate: 60%; the middle value lies beyond the limit too.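

In this assay compound 3 gives > 10000 nM, which is a limit of the assay and not a number. Placing 3-carboxyazetidin-1-yl on this saturated chain carbon instead of hydroxy gives an at least 1.5-fold higher number from compound 2 to compound 3 (0.18 log units; that floor lies within the scatter), so a second carboxy-bearing group with a nitrogen, this time in a four-membered ring, also yields no true number, and the real size of the change stays unknown. The step between compound 1 and compound 3 cannot be read, and the series now meets the same ceiling: the limit of > 10000 nM in this assay, at which 2 of the 3 values shown sit.

The compounds shown leave open whether the nitrogen or the carboxylic acid goes with these limits. A plain dimethylamino group, or a carboxylic acid without any nitrogen, at this same place would tell the two apart.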